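Swapping 2-fluorophenyl for benzyl: an expected modest weakening

The source may report more compounds than this note shows. Statements on the series, on what has been measured and on what is new or still open speak of the compounds shown alone.

Measured in a functional assay on a cell-free system (plasma, Homo sapiens), with a stated time of 3 min; a higher number here means a weaker inhibitor, a lower number a stronger inhibitor:
- compound 1 `O=C(NCc1cc(Cl)ccc1-n1cnnn1)[C@@H]1[C@@H]2C[C@@H]2CN1C(=O)[C@H](O)Cc1ccccn1` gives 1700 nM
- compound 2 `O=C(NCc1cc(Cl)ccc1-n1cnnn1)[C@@H]1[C@@H]2C[C@@H]2CN1C(=O)[C@H](O)c1ccccc1F` gives 580 nM

Of the two measured compounds, compound 2 has the lower number at 580 nM and is therefore the stronger inhibitor. Compound 3 `O=C(NCc1cc(Cl)ccc1-n1cnnn1)[C@@H]1[C@@H]2C[C@@H]2CN1C(=O)[C@H](O)Cc1ccccc1` has not yet been measured. It keeps the shared core of compound 2 and changes one group: benzyl in place of 2-fluorophenyl on a saturated chain carbon bound to a carbonyl carbon and an oxygen on a saturated carbon.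

Going by the values given here, only one measured step bears on this change, at the same carbon: a 2.9-fold lower number from compound 1 to compound 2 (0.47 log units; beyond the scatter). That step put 2-fluorophenyl in place of (pyridin-2-yl)methyl. Benzyl looks more like (pyridin-2-yl)methyl than like 2-fluorophenyl, so the new change may partly undo that modest gain. A single step is thin evidence, and nothing measured yet compares benzyl directly with (pyridin-2-yl)methyl.

In this assay the expected change is a modest rise in the number, a 1.7-fold higher number from compound 2 to compound 3 (0.24 log units; within the scatter). For compound 3 the estimated value is 1000 nM, with an expected range of 350 nM to 2800 nM.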

Compound 3, half-maximal inhibitory concentration: 970 nM
Beside the measured number, compound 3's estimate is 1.0-fold (0.01 log units) above it, and the stated range covers the measured number.
By their numbers in this assay, from the lowest: compounds 2, 3 and 1 (each within the scatter of the next, the first and the last beyond it).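

In this assay, benzyl at this carbon cannot be told apart from 2-fluorophenyl (a 1.7-fold higher number from compound 2 to compound 3 (0.22 log units; within the scatter)). Compound 3 also cannot be told apart from its pyridine partner, where phenyl stands in place of pyridin-2-yl (a 1.8-fold lower number from compound 1 to compound 3 (0.24 log units; within the scatter)), so the one gap beyond the scatter, between compound 1 and compound 2, now divides into two smaller steps, neither beyond the scatter on its own. Nothing measured here explains these numbers.

Going by these compounds alone, with only three compounds, the effect of the fluorine cannot be separated from that of the extra chain carbon, since benzyl differs from 2-fluorophenyl in both; an unsubstituted phenyl on this same saturated carbon would be the compound that separates them. From the compounds shown here alone, it also remains open how this carbon would respond to a longer chain such as 2-phenylethyl, or to a group of a different kind, such as an amine or a carboxylic acid, and whether any of these would move the number beyond the scatter of the three values seen so far.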